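The source may report more compounds than this note shows. Statements on the series, on what has been measured and on what is new or still open speak of the compounds shown alone.

Working notes on the series. Compound 1 `CN(Cc1ccc(OCCCNC(=N)N)cc1)c1nc2ccc(Oc3ccccc3)cc2s1` and compound 2 `CN(Cc1ccc(OCCCNC(=N)N)cc1)c1nc2ccc(Oc3cccc(C(F)(F)F)c3)cc2s1` share one core and differ only in the aryl group on the ether oxygen; compound 3 `CN(Cc1ccc(OCCCNC(=N)N)cc1)c1nc2ccc(Oc3ccc(F)cc3)cc2s1` is the next member and has not been measured. In an assay on SH-SY5Y cells for inhibition of Voltage-dependent N-type calcium channel subunit alpha-1B (Homo sapiens), read by FLIPR and calcium flux, with stated times of 600 s and 300 s, in the presence of a further agent that is not named here (on this read-out lower numbers stand for stronger inhibition and higher numbers for weaker inhibition), compound 1 gives 113000 nM, and in this assay compound 2 gives 202000 nM. Among the measured compounds shown here, the single measured step, a 1.8-fold higher number from compound 1 to compound 2 (0.25 log units; within the scatter), stays within the scatter. Compound 2 thus holds the highest of the two numbers, with compound 1 nearest, the gap between them within the scatter, so no order between them is claimed.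

The change to compound 3 is 4-fluorophenyl in place of 3-(trifluoromethyl)phenyl on an oxygen on an aromatic ring. For the measured compounds named here, only one measured step bears on it: a 1.8-fold higher number from compound 1 to compound 2 (0.25 log units; within the scatter) introduced the trifluoromethyl that now leaves, and it did not move the number beyond the scatter. Going by the values given here, no measured pair shows a fluorine entering on the aryl ring, so that part of the change rests on no data. The number for compound 3 is therefore expected to fall back toward that of compound 1, with a step of a 1.6-fold lower number from compound 2 to compound 3 (0.19 log units; within the scatter) expected but within the scatter. Compound 3 is estimated at 130000 nM, within 50000 nM to 350000 nM.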

Compound 3, half-maximal inhibitory concentration: 100000 nM
Compound 3: the middle estimate sits 1.3-fold (0.11 log units) above what was measured, and the stated range covers the measured number.
By their numbers in this assay, from the lowest: compounds 3, 1 and 2 (each within the scatter of the next, the first and the last beyond it).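

In this assay, the aryl group on the ether oxygen now gives a step beyond the scatter: 4-fluorophenyl in place of 3-(trifluoromethyl)phenyl gives a 2.0-fold lower number from compound 2 to compound 3 (0.31 log units; beyond the scatter) and counts as modest, so this position is not wholly indifferent to the change. Fluoro in place of hydrogen on an aromatic carbon, which no earlier pair covered, gives a 1.1-fold lower number from compound 1 to compound 3 (0.05 log units; within the scatter) and stays within the scatter, so the fluoro and hydrogen members cannot be told apart here, and the difference between compound 2 and compound 3 does not show that either aryl group departs clearly from the unsubstituted phenyl of compound 1. Nothing available explains this result.

As far as these compounds go, all three compounds carry a phenyl ring on the ether oxygen with a fluoro, trifluoromethyl or hydrogen substituent, so what an amine or a carboxylic acid on that ring would do remains open, as does the effect of fluoro elsewhere on the ring. The shared core and its guanidine chain are constant throughout, so the compounds shown say nothing about a longer chain or about an amine in place of the guanidine.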